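The source may hold more compounds than are shown below. What is called first, only, known or untested is meant among the compounds shown, and "the series" means these compounds.

Compound 1 `Fc1ccccc1NC(=S)N/N=C/c1ccc2ccccc2n1` in a functional assay on HeLa cells (Homo sapiens) for antiproliferative activity, read by sulforhodamine B assay, with a stated time of 72 h (a lower number here means a stronger inhibitor, a higher number a weaker inhibitor), reaches only a limit, > 100000 nM, which is the limit of > 100000 nM in this assay, at which 1 of the 2 values shown sits. Compound 2 `NC(=S)N/N=C/c1nc2ccccc2s1`, built on a different core, gives 5350 nM in this assay. Compound 3 `COc1cccc(NC(=S)N/N=C/c2ccc3ccccc3n2)c1` is not yet measured. It differs from compound 1 by 3-methoxyphenyl in place of 2-fluorophenyl on an amide-type nitrogen. Going by the values given here, no step between measured compounds is known here, so the expected step is an at least 1.2-fold lower number from compound 1 to compound 3 (0.09 log units; that floor lies within the scatter), none beyond the scatter. For compound 3 the estimated value in this assay is 80000 nM, ranging from 15000 nM to 300000 nM, and a limit rather than a number is again likely.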

Compound 3, half-maximal inhibitory concentration: 74500 nM
For compound 3 the middle estimate is 1.1-fold (0.03 log units) above the measured one; measured number inside the range.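

Going by these compounds alone, at the amide-type nitrogen, 3-methoxyphenyl in place of 2-fluorophenyl gives in this assay an at least 1.3-fold lower number from compound 1 to compound 3 (0.12 log units; that floor lies within the scatter) and so offers the first reading of a change at this place. Compound 1 gives > 100000 nM as a limit of the assay and not a number. Compound 3 brings a number to this series, but the step can be read only as a floor: the limit of > 100000 nM in this assay, at which 1 of the 3 values shown sits.

Open, on these data alone, is whether a carboxylic acid on the phenyl ring, or a longer alkyl chain in its place on this nitrogen, moves the number beyond the scatter.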